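Furan-3-yl swap in a series held at the limit

The source may hold more compounds than are shown below. What is called first, only, known or untested is meant among the compounds shown, and "the series" means these compounds.

Of the compounds shown here, three have been read in a functional assay on HCT-116 cells (Homo sapiens) for inhibition (on this read-out lower numbers stand for stronger inhibition and higher numbers for weaker inhibition), so far. Compound 1 (`CC(=O)Oc1ccc(/C=C/c2ccc3ccccc3c2)cc1`) gives > 5000 nM as a limit of the assay. Compound 2 (`C(=C/c1ccco1)\c1ccc2ccccc2c1`) gives > 5000 nM as a limit too, so it has no number to start from. Compound 3 (`C(=C\c1ccco1)\c1ccc2ccccc2c1`) gives > 5000 nM as a limit as well. The series therefore stands at the limit of > 5000 nM in this assay, at which 3 of the 3 values shown sit, and has no ranking. Within the data shown here, compound 4 (`C(=C/c1ccc2ccccc2c1)\c1ccoc1`) carries furan-3-yl in place of furan-2-yl on a double-bonded chain carbon bound to a double-bonded chain carbon as its one change. Among the measured compounds shown here, because a step that the two limits leave unreadable from compound 2 to compound 3 offers no size, no direction can be drawn from the only measured step, and no shift beyond the scatter is expected in this assay. The expected change is a step that the limit leaves unreadable from compound 2 to compound 4 and compound 4 will probably report as a limit again. Compound 4 is estimated at 7000 nM (expected range 3000 nM to 20000 nM).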

Compound 4, half-maximal inhibitory concentration: > 5000 nM
Compound 4: a limit, no number (the forecaster's own chance of this, stated with the estimate: 80%); the middle value is on the limit's open side.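

The furan-3-yl swap gives no readable step: compound 2 and compound 4 both stand as limits in this assay and no size or direction can be taken between them. The compounds shown leave open whether furan-2-yl and furan-3-yl differ at all on this read-out.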